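A few compounds are considered here, and "the series" means these few. Any claim that something is new, unique, unknown or untested is made for them only; others in the source may bear on it.

In a functional assay on P388 cells (Mus musculus) for inhibition (on this read-out higher numbers stand for weaker inhibition and lower numbers for stronger inhibition), compound 1 `O=S(=O)(c1ccccc1)n1ccc2cc(/C=C/c3ccc4ccccc4c3)ccc21` gives > 5000 nM, which is a limit of the assay and not a number. Compound 2 `O=S(=O)(c1ccccc1)n1ccc2cc(/C=C\c3ccc4ccccc4c3)ccc21` gives > 5000 nM, which is also a limit. Compound 2 therefore stands at the limit of > 5000 nM in this assay, at which 2 of the 2 values shown sit. Within the data shown here, the only measured comparison is a step that the two limits leave unreadable from compound 1 to compound 2, and it concerns (the fact that compounds 1 and 2 differ only in the configuration as drawn). Compound 3 `C(=C\c1ccc2[nH]ccc2c1)\c1ccc2ccccc2c1` carries hydrogen in place of phenylsulfonyl on an aromatic nitrogen. Among the measured compounds shown here, no measured step touches that nitrogen, so the data give no size or direction for this change. The expectation in this assay therefore stays close to where compound 2 sits, with no clear step in either direction and a real chance of another limit. The estimated step is a number no higher from compound 2 to compound 3 (the limit leaves the size open). For compound 3 the expected value is 5000 nM, with an estimated range from 1000 nM to 25000 nM.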

Compound 3, half-maximal inhibitory concentration: > 5000 nM
Compound 3 was reported as a limit (the forecaster's own chance of this, stated with the estimate: 60%); the middle value lies on the limit itself.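

Compound 2 and compound 3 are both reported only as limits and not as numbers, so the step between them cannot be read. The compounds shown leave open whether hydrogen in place of phenylsulfonyl changes inhibition at all, and how strongly any of them inhibits.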